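Methoxy added to the phenoxy ring of compound 3

The source may hold more compounds than are shown below. What is called first, only, known or untested is meant among the compounds shown, and "the series" means these compounds.

In an ADME assay on HepG2 cells (Homo sapiens) for cytotoxicity, read by luminescence, CellTiter-Glo and ATP content, with a stated time of 72 h (on this read-out lower numbers stand for an effect already at smaller amounts and higher numbers for an effect only at larger amounts of compound), compound 3 `COc1ccc(F)cc1CNCCCNc1ccnc2cc(Oc3ccccc3)ccc12` gives 1500 nM, the smallest of the three numbers measured, though the gap to compound 1 is within the scatter. Compound 1 `COc1ccc(F)cc1CNCCCNc1ccnc2cc(Cc3ccc(F)cc3Cl)ccc12` gives 2460 nM; the step of a 1.6-fold lower number from compound 1 to compound 3 (0.21 log units; within the scatter) puts phenoxy in place of 2-chloro-4-fluorobenzyl on an aromatic carbon and stays within the scatter. Compound 2 `COc1ccccc1Oc1ccc2c(NCCCNCc3cccc(OC)c3O)ccnc2c1` gives 11200 nM, beyond the scatter from compound 3, but compound 2 differs from compound 3 in more than one place, so no single step can be read from that pair. Compound 4 `COc1ccc(F)cc1CNCCCNc1ccnc2cc(Oc3ccccc3OC)ccc12` carries methoxy in place of hydrogen on an aromatic carbon. Going by the values given here, no measured step alters a group on the phenoxy ring alone; the one step measured exchanges the whole group at that aromatic carbon without moving beyond the scatter. Compound 2 also carries 2-methoxyphenoxy and gives the highest number, but its other differences leave that unassigned. Compound 4 is therefore estimated at 2200 nM, range 900 nM to 6000 nM. The expected step of a 1.5-fold higher number from compound 3 to compound 4 (0.17 log units; within the scatter) is small, tilted toward a higher number, and likely within the scatter.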

Compound 4, half-maximal effective concentration in the HepG2 assay: 6400 nM
Compound 4: the middle estimate sits 2.9-fold (0.46 log units) below what was measured; the whole stated range lies below it.
By their numbers in the HepG2 assay, from the lowest: compounds 3 and 1 (each within the scatter of the next); then compounds 4 and 2 (each within the scatter of the next).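

Going by these compounds alone, in the HepG2 assay methoxy in place of hydrogen, ortho to a large group, is the first change made on the phenoxy ring alone, and it moves the number beyond the scatter (a 4.3-fold higher number from compound 3 to compound 4 (0.63 log units; beyond the scatter)). With 2-methoxyphenoxy on the aromatic carbon, the exchange of the 2-chloro-4-fluorobenzyl group also lies beyond the scatter (a 2.6-fold higher number from compound 1 to compound 4 (0.42 log units; beyond the scatter)), while the exchange on the saturated chain carbon stays within it (a 1.8-fold lower number from compound 2 to compound 4 (0.24 log units; within the scatter)). In a physicochemical assay for acid dissociation, compound 3 gives 9.28 and compound 4 gives 9.28, so the two do not differ on that read-out.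

Nothing available accounts for the higher number with methoxy. Open, on these data alone, is whether ethoxy or an amine in the same place would give a step of similar size.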